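The source may report more compounds than this note shows. Statements on the series, on what has been measured and on what is new or still open speak of the compounds shown alone.

The measured compounds:
compound 1, `CC(Oc1ccccc1-c1ccccc1)C1=NCCO1`: 5890 nM
compound 2, `CC(Oc1ccccc1-c1ccccc1O)C1=NCCN1`: 1620 nM
compound 3, `CC(Sc1ccccc1-c1ccccc1)C1=NCCN1`: 708 nM

These three compounds were tested in an assay on CHO cells for displacement of a labelled ligand from Alpha-2C adrenergic receptor (Homo sapiens); a higher number here means a weaker inhibitor, a lower number a stronger inhibitor. Within this set compound 2 stands second highest of the three numbers. Compound 3 lies nearest to it, with a lower number, and the gap between the two is beyond the usual scatter of the measurement. Compound 1 lies furthest from compound 2, with a higher number, and that gap is also beyond the scatter.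

Compound 4, `CC(Oc1ccccc1-c1ccncc1)C1=NCCN1`, has not yet been measured in this assay. It differs from compound 2 in a single place: pyridin-4-yl in place of 2-hydroxyphenyl on an aromatic carbon. For the measured compounds named here, no pair of measured compounds differs in only one place, so the size of such a change cannot be read from a close comparison, and the expectation rests only on the spread of the three measured values. The expected step is a 1.5-fold higher number from compound 2 to compound 4 (0.19 log units; within the scatter), small and, if anything, towards a weaker inhibitor. For compound 4 in this assay the estimate is 2500 nM, with a range from 800 nM to 8000 nM.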

Compound 4, inhibition constant: 1450 nM
Beside the measured number, compound 4's estimate is 1.7-fold (0.24 log units) above it; low and high end bracket the measured number.
By their numbers in this assay, from the lowest: compound 3; then compounds 4 and 2 (each within the scatter of the next); then compound 1.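

In this assay, for the compounds shown here, putting pyridin-4-yl in place of 2-hydroxyphenyl on this aromatic carbon gives a 1.1-fold lower number from compound 2 to compound 4 (0.05 log units; within the scatter), the first comparison in the set between compounds that differ in one place only. At this position, ortho to a group of 8 heavy atoms, the measurement does not tell the two rings apart, even though the group that leaves has a carbon-only ring and a hydrogen-bond donor, while the group that enters has a ring with one hetero atom and no donor. No supporting measurement accounts for the closeness of the two numbers.

The compounds shown leave open how an unsubstituted phenyl, a pyridin-3-yl or a 4-aminophenyl group would stand on this carbon, so the hydroxyl and the ring nitrogen cannot yet be judged separately. They also leave open whether the same exchange would give so small a step on the core of compound 1 or on the core of compound 3, since neither has a partner differing from it in one place.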